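Chloro for methoxy on an unresponsive amide series

A few compounds are considered here, and "the series" means these few. Any claim that something is new, unique, unknown or untested is made for them only; others in the source may bear on it.

The shared core of compound 1 `O=C(Nc1ccc(C(F)(F)F)cc1)c1nccc2ccccc12` carries an amide to a substituted benzene. In a functional assay on NUGC-3 cells (Homo sapiens) for inhibition, read by sulforhodamine B assay, with a stated time of 48 h (a lower number here means a stronger inhibitor of growth, a higher number a weaker inhibitor of growth), compound 1 gives > 10000 nM, which is a limit of the assay and not a number. Compound 2 `O=C(Nc1ccc(O)cc1)c1nccc2ccccc12` replaces the trifluoromethyl with a hydroxy group. In this assay compound 2 gives > 10000 nM, again a limit. Compound 3 `COc1ccc(NC(=O)c2nccc3ccccc23)cc1` carries a methoxy group instead. In this assay compound 3 gives > 10000 nM, once more a limit. Compound 3 therefore stands nowhere above or below its neighbours: all three values sit together at the limit of > 10000 nM in this assay, at which 3 of the 3 values shown sit. The steps a step that the two limits leave unreadable from compound 1 to compound 2, a step that the two limits leave unreadable from compound 1 to compound 3 and a step that the two limits leave unreadable from compound 2 to compound 3 are all unreadable for the same reason.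

Compound 4 `O=C(Nc1ccc(Cl)cc1)c1nccc2ccccc12` is the next variation: chloro in place of methoxy on an aromatic carbon. Among the measured compounds shown here, none of the measured steps gives a readable size, so no direction can be drawn from them for the step to compound 4 in this assay. Since compound 3 stays at its limit > 10000 nM, the most probable outcome is that compound 4 is also reported only as a limit. Compound 4 is estimated at 10000 nM, within 2500 nM to 40000 nM. This estimate means an expected step of a number no higher from compound 3 to compound 4 (the limit leaves the size open), not beyond the scatter.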

Compound 4, concentration for 50% growth inhibition: > 10000 nM
Compound 4 gave a limit, no number; the forecaster's own chance of this, stated with the estimate: 70%; the middle value lies on the limit itself.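

Among the compounds shown here, compound 4 also stops at a limit of the assay, not a number, so no step from compound 1, compound 2 or compound 3 to compound 4 can be read in this assay. All four compounds sit together: the limit of > 10000 nM in this assay, at which 4 of the 4 values shown sit. The compounds shown leave open whether any of these four groups differs from another in growth inhibition, and by how much.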